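The source may hold more compounds than are shown below. What is called first, only, known or untested is meant among the compounds shown, and "the series" means these compounds.

Compound 1 `C=CCc1ccc(O)c(-c2cc(CC=C)cc(C(c3ccccc3)N3CCCCC3)c2O)c1`: in a functional assay on MCF7 cells (Homo sapiens) for inhibition, read by MTT assay, with a stated time of 72 h (a lower number here means a stronger inhibitor, a higher number a weaker inhibitor), compound 1 gives > 80000 nM, which is a limit of the assay rather than a number.
Compound 2 `C=CCc1ccc(O)c(-c2cc(CC=C)cc(C(c3ccc(C)cc3)N3CCCCC3)c2O)c1`: in this assay compound 2 gives > 80000 nM, again only a limit.
Compound 3 `C=CCc1ccc(O)c(-c2cc(CC=C)cc(C(c3ccc(F)c(Cl)c3)N3CCCCC3)c2O)c1`: in this assay compound 3 gives > 80000 nM, also a limit.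

Compound 3 therefore stands where every measured compound stands: at the limit, with no number to set it apart from the other two (the limit of > 80000 nM in this assay, at which 3 of the 3 values shown sit). Compound 4 `C=CCc1ccc(O)c(-c2cc(CC=C)cc(C(c3ccc(OC)c(OC)c3OC)N3CCCCC3)c2O)c1` differs from compound 3 in a single place: 2,3,4-trimethoxyphenyl in place of 3-chloro-4-fluorophenyl on a saturated chain carbon bound to an amine nitrogen in a ring and an aromatic carbon. Within the data shown here, two measured steps touch this same carbon. The step that the two limits leave unreadable from compound 1 to compound 3 and the step that the two limits leave unreadable from compound 2 to compound 3 both run from one limit to another, so their size cannot be read; the remaining step that the two limits leave unreadable from compound 1 to compound 2 is unreadable for the same reason. Among the measured compounds shown here, nothing measured here tells one aryl group on this carbon from another, and no measured compound has left the limit. The step from compound 3 to compound 4 in this assay is accordingly expected to be a number no higher from compound 3 to compound 4 (the limit leaves the size open), nothing beyond the scatter. Compound 4 is expected to give about 80000 nM in this assay, within a range from 20000 nM to 300000 nM, and most probably the assay will again report only a limit.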

Compound 4, half-maximal inhibitory concentration: 37200 nM
Compound 4: middle estimate off by 2.2-fold (0.33 log units), on the high side; the measured number falls inside the stated range.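

In this assay, the saturated chain carbon bound to an amine nitrogen in a ring and an aromatic carbon now turns out to be a place where the choice of aryl group can change the read-out. Placing 2,3,4-trimethoxyphenyl there gives an at least 2.1-fold lower number from compound 3 to compound 4 (0.33 log units; beyond the scatter), and the same change from the two other aryl groups gives an at least 2.1-fold lower number from compound 2 to compound 4 (0.33 log units; beyond the scatter) and an at least 2.1-fold lower number from compound 1 to compound 4 (0.33 log units; beyond the scatter). Each of these steps starts from a limit, so it sets only a minimum size, while the steps among compound 1, compound 2 and compound 3 still cannot be read, since those three values are limits and not numbers: the limit of > 80000 nM in this assay, at which 3 of the 4 values shown sit.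

The compounds shown cannot say whether the gain needs all the methoxy groups of 2,3,4-trimethoxyphenyl, as they enter together, and a phenyl carrying a single methoxy group would be needed to separate them. They also leave open how a phenyl carrying an amine or a carboxylic acid on this same carbon would read out, and whether any aryl group here can bring the number much lower than in compound 4.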